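Thiophene for iodophenyl at the saturated ring carbon

The compounds below may be only part of what the source reports. "The series", "measured", "known", "first", "only" and "open" are said of these compounds alone.

Compound 1 `CC1=NC(C)=C(C(=O)O)C(c2cccc(Br)c2)/C1=C(\O)OC/C=C/c1ccccc1`: 790 nM
Compound 2 `CC1=NC(C)=C(C(=O)O)C(c2cccc(I)c2)/C1=C(\O)OC/C=C/c1ccccc1`: 1700 nM

In a functional assay on IMR-32 cells for inhibition of Voltage-dependent N-type calcium channel subunit alpha-1B (Homo sapiens), read by calcium flux (on this read-out lower numbers stand for stronger inhibition and higher numbers for weaker inhibition), compound 2 stands highest of the two numbers; its nearest neighbour, compound 1, gives 790 nM, and the step of a 2.2-fold higher number from compound 1 to compound 2 (0.33 log units; beyond the scatter) lies beyond the scatter. Compound 3 `CC1=NC(C)=C(C(=O)O)C(c2ccsc2)/C1=C(\O)OC/C=C/c1ccccc1` differs from compound 2 by thiophen-3-yl in place of 3-iodophenyl on a saturated ring carbon. For the measured compounds named here, no measured step exchanges one aromatic ring for another; the only step known, a 2.2-fold higher number from compound 1 to compound 2 (0.33 log units; beyond the scatter), is modest. For compound 3 a step within the scatter, in either direction, is therefore expected, a 1.1-fold lower number from compound 2 to compound 3 (0.05 log units; within the scatter). Compound 3 is estimated at 1500 nM, within 500 nM to 5000 nM.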

Compound 3, half-maximal inhibitory concentration: 2900 nM
For compound 3 the middle estimate is 1.9-fold (0.29 log units) below the measured one; the range from low to high includes it.
By their numbers in this assay, from the lowest: compound 1; then compounds 2 and 3 (each within the scatter of the next).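

Replacing the six-membered carbon ring with a five-membered ring bearing one hetero atom at this saturated ring carbon is a larger change than the halogen exchange, yet it gives a 1.7-fold higher number from compound 2 to compound 3 (0.23 log units; within the scatter) in this assay and stays inside the scatter. Against the 3-bromophenyl group, the same ring gives a 3.7-fold higher number from compound 1 to compound 3 (0.56 log units; beyond the scatter) and lies beyond the scatter, so compound 1 keeps the lowest number of the set. No evidence is available to explain either step.

The compounds shown leave open how a pyridine ring or thiophen-2-yl would read at this carbon. They also leave open whether a bromo group on the thiophene would bring the number back to that of compound 1.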